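One Stereocentre Flipped: From Compound 2 to Compound 3

The source may report more compounds than this note shows. Statements on the series, on what has been measured and on what is new or still open speak of the compounds shown alone.

In a functional assay on cells (blood, Homo sapiens) for inhibition, read by chemiluminescence, with a stated time of 30 min (on this read-out higher numbers stand for weaker inhibition and lower numbers for stronger inhibition), compound 1 `CC1(C)CC(=O)C(C(=S)SCCO)=C(Nc2ccc(Cl)cc2Cl)C1` gives only a limit, > 100 ug/mL. Compound 2 `CC(=O)OC[C@H]1O[C@@H](SC(=S)C2=C(Nc3ccc(Cl)cc3Cl)CC(C)(C)CC2=O)[C@H](OC(C)=O)[C@@H](OC(C)=O)[C@@H]1OC(C)=O` likewise gives only a limit in this assay, > 100 ug/mL. Compound 2 therefore stands at the limit of > 100 ug/mL in this assay, at which 2 of the 2 values shown sit, with no number beneath it. Compound 3 `CC(=O)OC[C@H]1O[C@@H](SC(=S)C2=C(Nc3ccc(Cl)cc3Cl)CC(C)(C)CC2=O)[C@H](OC(C)=O)[C@@H](OC(C)=O)[C@H]1OC(C)=O` differs from compound 2 in one place: the two compounds have the same atoms and bonds and differ only in configuration as drawn: 1 of 5 stereo elements differ; a stereocentre at a saturated ring carbon is drawn R in compound 2 and S in compound 3. No measured step between compounds is shown, so in this assay the change is expected to bring no shift beyond the scatter, giving the estimated step that the limit leaves unreadable from compound 2 to compound 3. Since compound 2 sits at the limit of > 100 ug/mL in this assay, at which 2 of the 2 values shown sit, compound 3 is estimated at 150 ug/mL, within 50 ug/mL to 500 ug/mL, most likely reported again only as a limit.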

Compound 3, half-maximal inhibitory concentration: 5.94 ug/mL
For compound 3 the middle estimate is 25-fold (1.40 log units) above the measured one, and the stated range ends above it.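

In this assay, changing the stereocentre at this saturated ring carbon from R to S gives an at least 16-fold lower number from compound 2 to compound 3 (1.22 log units; beyond the scatter). Compounds 1 and 2 gave only limits. Within the data shown here, compound 3, at 5.94 ug/mL, is the first to give a number and shows that this position responds to configuration. The shift can be assigned to this one stereocentre, because the structures offer no other change: the fact that compounds 2 and 3 differ only in the configuration as drawn

The compounds shown leave open whether the other stereo elements matter as much. They also leave open whether the S configuration would keep this inhibition with an amine at this ring carbon.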